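A few compounds are considered here, and "the series" means these few. Any claim that something is new, unique, unknown or untested is made for them only; others in the source may bear on it.

Measured so far in a functional assay on HeLa cells (Homo sapiens) for antiproliferative activity, read by CCK-8 assay, with a stated time of 48 h; on this read-out lower numbers stand for stronger inhibition and higher numbers for weaker inhibition: compound 1 `COc1ccc(/C=C\c2cc(OC)c(OC)c(OC)c2)cc1OCc1ccc(CN2CCCCC2C(=O)O)cc1` with 14200 nM; compound 2 `COc1ccc(/C=C\c2cc(OC)c(OC)c(OC)c2)cc1OCc1ccc(CN2CCCCC2C(=O)NCCNC(=O)OC(C)(C)C)cc1` with 2000 nM; compound 3 `COc1ccc(/C=C\c2cc(OC)c(OC)c(OC)c2)cc1OCc1ccc(CN2CC(C(=O)O)C2)cc1` with 6500 nM.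

Compound 1 stands highest of the three numbers, with compound 3 nearest and compound 2 furthest. Compound 4 `COc1ccc(/C=C\c2cc(OC)c(OC)c(OC)c2)cc1OCc1ccc(CN2CC[C@H](O)C2)cc1` differs from compound 1 by 3-hydroxypyrrolidin-1-yl in place of 2-carboxypiperidin-1-yl on a saturated chain carbon bound to an aromatic carbon. Both measured steps alter the same place on the shared core of compound 1: a 7.1-fold lower number from compound 1 to compound 2 (0.85 log units; beyond the scatter) and a 2.2-fold lower number from compound 1 to compound 3 (0.34 log units; beyond the scatter). Each lies beyond the scatter and each runs toward a lower number, so a modest step in the same direction is expected in this assay for compound 4, namely a 3.2-fold lower number from compound 1 to compound 4 (0.50 log units; beyond the scatter). In this assay compound 4 is expected to give 4500 nM, with a range from 1300 nM to 14000 nM.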

Compound 4, half-maximal inhibitory concentration: 10500 nM
For compound 4 the middle estimate is 2.3-fold (0.37 log units) below the measured one, within the range that was stated.
By their numbers in this assay, from the lowest: compound 2; then compounds 3, 4 and 1 (each within the scatter of the next, the first and the last beyond it).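

In this assay, 3-hydroxypyrrolidin-1-yl in place of 2-carboxypiperidin-1-yl gives a 1.4-fold lower number from compound 1 to compound 4 (0.13 log units; within the scatter), and in place of 3-carboxyazetidin-1-yl it gives a 1.6-fold higher number from compound 3 to compound 4 (0.21 log units; within the scatter); both steps lie within the scatter. At this saturated chain carbon, then, a ring carrying hydroxy and no carboxylic acid reads alike with each of the two acids, and the earlier steps had not shown that an exchange here can leave the number within the scatter. Nothing available accounts for this result. Open, going by these compounds, is how a free primary amine in place of the tert-butoxycarbonyl-protected amine of compound 2 would read, and whether the opposite configuration of the 3-hydroxypyrrolidin-1-yl group would shift the number.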